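From Cyclopropylsulfonyl to Piperazinylcarbonyl on a Shared Core

This account rests on a few compounds, and the source may have more. Where it says the series, first, only, none or still open, it means among the compounds named here.

Of the compounds shown here, three built on one shared core have been tested in a functional assay on DU-145 cells (Homo sapiens) for antiproliferative activity, read by MTT assay, with a stated time of 3 days; on this read-out lower numbers stand for stronger inhibition and higher numbers for weaker inhibition. Compound 1 `COc1cc(O)c2c(=O)cc(-c3ccc(NS(C)(=O)=O)cc3)oc2c1OC(C)C` gives 19100 nM, compound 2 `CCS(=O)(=O)Nc1ccc(-c2cc(=O)c3c(O)cc(OC)c(OC(C)C)c3o2)cc1` gives 17000 nM, and compound 3 `COc1cc(O)c2c(=O)cc(-c3ccc(NS(=O)(=O)C4CC4)cc3)oc2c1OC(C)C` gives 48700 nM. Compound 3 thus carries the highest of the three numbers, meaning the weakest inhibition; the two steps leading to it, a 2.5-fold higher number from compound 1 to compound 3 (0.41 log units; beyond the scatter) and a 2.9-fold higher number from compound 2 to compound 3 (0.46 log units; beyond the scatter), are both beyond the scatter, whereas a 1.1-fold lower number from compound 1 to compound 2 (0.05 log units; within the scatter) stays within it.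

Compound 4 `COc1cc(O)c2c(=O)cc(-c3ccc(NC(=O)N4CCN(C)CC4)cc3)oc2c1OC(C)C` alters compound 3 by (4-methylpiperazin-1-yl)carbonyl in place of cyclopropylsulfonyl on a nitrogen on an aromatic ring. Going by the values given here, none of the measured steps covers an exchange of this kind: each of them only varies the group on the sulfonyl sulfur, while here the whole cyclopropylsulfonyl leaves and a (4-methylpiperazin-1-yl)carbonyl enters on the same nitrogen. The measured steps show only that cyclopropyl gave a higher number than methyl or ethyl, so losing it might move the number back toward those of compounds 1 and 2, but the direction remains uncertain. The expected step is a 1.9-fold lower number from compound 3 to compound 4 (0.29 log units; within the scatter). Compound 4 is estimated at 25000 nM in this assay, with a range from 6000 nM to 100000 nM.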

Compound 4, half-maximal inhibitory concentration: 12500 nM
For compound 4 the middle estimate is 2.0-fold (0.30 log units) above the measured one; measured number inside the range.
By their numbers in this assay, from the lowest: compounds 4, 2 and 1 (each within the scatter of the next); then compound 3.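

In this assay, the nitrogen on the aromatic ring accepts a group quite unlike a sulfonyl: (4-methylpiperazin-1-yl)carbonyl in place of cyclopropylsulfonyl gives a clear step (a 3.9-fold lower number from compound 3 to compound 4 (0.59 log units; beyond the scatter)). Against the two smaller sulfonyl groups, the same exchange stays within the scatter, both for ethylsulfonyl (a 1.4-fold lower number from compound 2 to compound 4 (0.13 log units; within the scatter)) and for methylsulfonyl (a 1.5-fold lower number from compound 1 to compound 4 (0.18 log units; within the scatter)), so a sulfonyl is not needed to reach this level of activity, and among these four compounds only compound 3 stands apart. Nothing measured here explains these numbers.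

The compounds shown leave open which part of the new group counts, the carbonyl or the ring with its methyl. A morpholine in place of the 4-methylpiperazine, or a plain acetyl on the same nitrogen, would help separate the two.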